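Swapping the urea aryl group on a shared core

The source may report more compounds than this note shows. Statements on the series, on what has been measured and on what is new or still open speak of the compounds shown alone.

Compound 1 `O=C(Nc1ccc(Cl)cc1)Nc1ccc(Nc2ncnc3c2OCCN3)cc1` has the lowest number of the three measured compounds in an assay on isolated protein for inhibition of proto-oncogene tyrosine-protein kinase receptor Ret variant V804M (Homo sapiens), read by 33P incorporation, with stated times of 15 min and 40 min (on this read-out lower numbers stand for stronger inhibition and higher numbers for weaker inhibition), giving 2280 nM. Compound 2 `COc1cccc(NC(=O)Nc2ccc(Nc3ncnc4c3OCCN4)cc2)c1` gives 5290 nM and compound 3 `O=C(Nc1ccc(Nc2ncnc3c2OCCN3)cc1)Nc1cccs1` gives 8640 nM; the steps run a 2.3-fold higher number from compound 1 to compound 2 (0.37 log units; beyond the scatter) and a 3.8-fold higher number from compound 1 to compound 3 (0.58 log units; beyond the scatter), while between the two weaker compounds the step of a 1.6-fold higher number from compound 2 to compound 3 (0.21 log units; within the scatter) stays inside the scatter.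

Compound 4 `CC(C)(C)c1csc(NC(=O)Nc2ccc(Nc3ncnc4c3OCCN4)cc2)n1` is not yet measured. It differs from compound 1 by 4-(tert-butyl)-1,3-thiazol-2-yl in place of 4-chlorophenyl on an amide-type nitrogen. Both measured steps away from compound 1 change the same group on the same amide-type nitrogen, and both raise the number, the five-membered thiophen-2-yl more than the 3-methoxyphenyl. Compound 4 again places a five-membered ring there, so a rise beyond the scatter is expected, tempered by the absence of any measured tert-butyl-bearing analogue. For compound 4 the expected step is a 2.1-fold higher number from compound 1 to compound 4 (0.32 log units; beyond the scatter). Compound 4 is estimated at 4800 nM, with a range of 1600 nM to 14000 nM.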

Compound 4, half-maximal inhibitory concentration: 5170 nM
Estimate against measurement, compound 4: 1.1-fold (0.03 log units) below; low and high end bracket the measured number.
By their numbers in this assay, from the lowest: compound 1; then compounds 4, 2 and 3 (each within the scatter of the next).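

In this assay the 4-(tert-butyl)-1,3-thiazol-2-yl group on the amide-type nitrogen also falls short of 4-chlorophenyl (a 2.3-fold higher number from compound 1 to compound 4 (0.36 log units; beyond the scatter)), so all three replacements shown raise the number at this position. The new group does not separate from the other two replacements, with both comparisons staying within the scatter (a 1.7-fold lower number from compound 3 to compound 4 (0.22 log units; within the scatter); a 1.0-fold lower number from compound 2 to compound 4 (0.01 log units; within the scatter)), and so these three differently built groups cannot be ranked against one another, even though this one brings a second ring hetero atom and a tert-butyl group. No measurement shown here accounts for this pattern.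

The compounds shown leave open what the tert-butyl group contributes, as none carries a plain 1,3-thiazol-2-yl group. Also open, on these data alone, is whether the chlorine of compound 1 matters, or how an unsubstituted phenyl ring or a phenyl ring bearing a morpholine would compare at this nitrogen.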